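Imidazole positional isomer in the aminomethyl side chain

A few compounds are considered here, and "the series" means these few. Any claim that something is new, unique, unknown or untested is made for them only; others in the source may bear on it.

Measured so far:
compound 1 `Cc1cc(NCCCc2ccccn2)n2nc(C)c(-c3ccccc3)c2n1` — 5900 nM
compound 2 `Cc1cc(NCc2ncc[nH]2)n2nc(C)c(-c3ccccc3)c2n1` — < 5000 nM

In a physicochemical assay for solubility, read by HPLC, using the shake flask method, measured as kinetic solubility, with a stated time of 2 h, at pH 7.4 (on this read-out lower numbers stand for lower solubility and higher numbers for higher solubility), compound 1 gives 5900 nM. For compound 2 the read-out is a limit of the assay, < 5000 nM, and not a number; it is the limit described as the limit of < 5000 nM in this assay, at which 1 of the 2 values shown sits. Among the measured compounds shown here, the one measured step, an at least 1.1-fold lower number from compound 1 to compound 2 (0.07 log units; that floor lies within the scatter), therefore fixes only a floor for compound 2 and leaves open how far below the limit it sits.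

Compound 3 `Cc1cc(NCc2c[nH]cn2)n2nc(C)c(-c3ccccc3)c2n1` has the same atoms as compound 2, joined differently: 1H-imidazol-4-yl in place of 1H-imidazol-2-yl on a saturated chain carbon bound to a nitrogen on an aromatic ring. For the measured compounds named here, no measured pair in the set shows this kind of change, the imidazole ring simply attached through another ring carbon, so the only guide is the standing of compound 2 itself, which is a limit. Going by the values given here, nothing in the numbers so far points to a move in either direction beyond the scatter; the step that the limit leaves unreadable from compound 2 to compound 3 is expected to be small, with a real chance that this assay again reports only the limit. Compound 3 is therefore estimated at 4000 nM, within a range of 1000 nM to 12000 nM.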

Compound 3, solubility: 14600 nM
The estimate for compound 3 lay 3.7-fold (0.56 log units) below the measured number, outside the stated range (above it).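

In this assay the two imidazole isomers do not read alike: with the same atoms and the same counts of donors and acceptors, 1H-imidazol-4-yl in place of 1H-imidazol-2-yl on a saturated chain carbon bound to a nitrogen on an aromatic ring gives an at least 2.9-fold higher number from compound 2 to compound 3 (0.46 log units; beyond the scatter). That step is only a floor, and the read-out of compound 2 remains a limit and not a number: the limit of < 5000 nM in this assay, at which 1 of the 3 values shown sits. Set against the 2-(pyridin-2-yl)ethyl group at this place, 1H-imidazol-4-yl gives a 2.5-fold higher number from compound 1 to compound 3 (0.39 log units; beyond the scatter), so among these three compounds the highest number belongs to an imidazole, while the other imidazole isomer gives only a limit.

On these data alone, how far compound 2 lies from its limit stays open, and with it the true size of the step between the two isomers. Also open, as far as these compounds go, is whether a 1-methyl-1H-imidazol-4-yl or a 1H-pyrazol-4-yl group on the same saturated chain carbon would read closer to compound 3 or to compound 2.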